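A few compounds are considered here, and "the series" means these few. Any claim that something is new, unique, unknown or untested is made for them only; others in the source may bear on it.

Within the data shown here, compound 3 `CCCCN(C)Cc1c(C(F)(F)F)nc2n(-c3c(C)cc(C)cc3C)c(Cl)cn12` gives 310 nM in an assay on cells for displacement of a labelled ligand from corticotropin-releasing factor receptor 1 (Homo sapiens), with a stated time of 100 min (on this read-out lower numbers stand for stronger inhibition and higher numbers for weaker inhibition), the highest number among the three compounds measured so far. Compound 1 `CCCN(CC1CC1)C(=O)c1c(C)nc2n(-c3c(C)cc(C)cc3C)c(Cl)cn12` gives 61 nM in this assay, while compound 2 `CCN(Cc1c(C(F)(F)F)nc2n(-c3c(C)cc(C)cc3C)c(Cl)cn12)CC1CC1` gives 9 nM in this assay. Among the measured compounds shown here, the one single-point step that bears on the next change runs a 34-fold higher number from compound 2 to compound 3 (1.54 log units; beyond the scatter). Compound 4 `CCN(CCC1CC1)Cc1c(C(F)(F)F)nc2n(-c3c(C)cc(C)cc3C)c(Cl)cn12` carries (2-cyclopropylethyl)(ethyl)amino in place of butyl(methyl)amino on a saturated chain carbon bound to an aromatic carbon; cut one bond further out, the same difference reads (butyl(methyl)amino)methyl to ((2-cyclopropylethyl)(ethyl)amino)methyl. This change largely undoes the step of a 34-fold higher number from compound 2 to compound 3 (1.54 log units; beyond the scatter), restoring the ethyl group on the nitrogen and bringing back the three-membered ring, now on a chain one carbon longer. A step of similar size in the opposite direction, toward a lower number, is therefore the plainest expectation, though the longer chain leaves room for it to fall short of a full return. Compound 4 is expected to give 20 nM in this assay, within a range of 6 nM to 80 nM. The step of a 16-fold lower number from compound 3 to compound 4 (1.19 log units; beyond the scatter) is the expected consequence.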

Compound 4, inhibition constant: 13 nM
The estimate for compound 4 lay 1.5-fold (0.19 log units) above the measured number; low and high end bracket the measured number.
By their numbers in this assay, from the lowest: compounds 2 and 4 (each within the scatter of the next); then compound 1; then compound 3.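

In this assay, the step of a 24-fold lower number from compound 3 to compound 4 (1.38 log units; beyond the scatter) shows that the large loss seen with butyl(methyl)amino at this place is not a limit on the size of the amine, since (2-cyclopropylethyl)(ethyl)amino is the larger group and gives the lower number. The step of a 1.4-fold higher number from compound 2 to compound 4 (0.16 log units; within the scatter) adds that the three-membered ring tolerates cyclopropylmethyl in place of cyclopropyl on a saturated chain carbon bound to an amine nitrogen, leaving the two amines indistinguishable in this read-out. Nothing shown here explains these differences.

Compound 3 and compound 4 differ in both the ethyl group on the nitrogen and the ring, so the share of each remains unresolved; a butyl(ethyl)amino group would separate them. Going by these compounds, how far the chain can grow is also open, for example with a 3-cyclopropylpropyl group on the nitrogen.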